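The compounds below may be only part of what the source reports. "The series", "measured", "known", "first", "only" and "open" are said of these compounds alone.

Measured in a functional assay on MDA-MB-231 cells (Homo sapiens) for cytotoxicity, read by MTT assay, with a stated time of 72 h; on this read-out lower numbers stand for stronger inhibition and higher numbers for weaker inhibition:
- Compound 1 `O=C1c2c[n+]([O-])c3ccccc3c2C(=O)c2c1c1ccccc1n2CCCCN1CCCCC1`: 610 nM
- Compound 2 `CN1CCN(CCCn2c3c(c4ccccc42)C(=O)c2c[n+]([O-])c4ccccc4c2C3=O)CC1`: 390 nM
- Compound 3 `O=C1c2c[n+]([O-])c3ccccc3c2C(=O)c2c1c1ccccc1n2CCN1CCCCC1`: 1050 nM

Compound 3 lies within the scatter of compound 1, as a 1.7-fold higher number from compound 1 to compound 3 (0.24 log units; within the scatter) shows. It separates only from compound 2, and modestly, with a 2.7-fold higher number from compound 2 to compound 3 (0.43 log units; beyond the scatter).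

The next compound is compound 4 `O=C1c2c[n+]([O-])c3ccccc3c2C(=O)c2c1c1ccccc1n2CCCN1CCC(O)CC1`, which is to be tested in this assay. Compared with compound 3, it carries this change: (4-hydroxypiperidin-1-yl)methyl in place of piperidin-1-yl on a saturated chain carbon, two bonds along the chain from an aromatic nitrogen. Cut one bond further out, the change reads 2-(piperidin-1-yl)ethyl to 3-(4-hydroxypiperidin-1-yl)propyl.

The closest guide is a 2.7-fold higher number from compound 2 to compound 3 (0.43 log units; beyond the scatter), where piperidin-1-yl takes the place of a substituted methyl group at the same place, the reverse of the present exchange. a 1.7-fold higher number from compound 1 to compound 3 (0.24 log units; within the scatter) points the same way, though it stays within the scatter. Among the measured compounds shown here, no measured compound carries the (4-hydroxypiperidin-1-yl)methyl group, so the contribution of the hydroxy-bearing ring remains unknown and the expectation is held loosely.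

A modest move toward a lower number is therefore expected, near the edge of the scatter, and the expected change is a 1.8-fold lower number from compound 3 to compound 4 (0.26 log units; within the scatter). Compound 4 is estimated at 580 nM, with an expected range of 260 nM to 1300 nM.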

Compound 4, half-maximal inhibitory concentration: 280 nM
Estimate against measurement, compound 4: 2.1-fold (0.32 log units) above, within the range that was stated.
By their numbers in this assay, from the lowest: compounds 4, 2, 1 and 3 (each within the scatter of the next, the first and the last beyond it).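

In this assay, the exchange of 2-(piperidin-1-yl)ethyl for 3-(4-hydroxypiperidin-1-yl)propyl gives a 3.8-fold lower number from compound 3 to compound 4 (0.57 log units; beyond the scatter), the first result among these compounds for a hydroxy-bearing ring at this place, and it shows that such a ring is compatible with a lower number than the piperidin-1-yl group on the shorter chain gives. With 4-hydroxypiperidin-1-yl in place of (piperidin-1-yl)methyl on a saturated chain carbon, three bonds along the chain from an aromatic nitrogen, the result is a 2.2-fold lower number from compound 1 to compound 4 (0.34 log units; beyond the scatter), while a 1.4-fold lower number from compound 2 to compound 4 (0.14 log units; within the scatter) leaves 4-hydroxypiperidin-1-yl and 4-methylpiperazin-1-yl unresolved at that place. The data offer no evidence that would explain these steps.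

The compounds shown include no 3-(piperidin-1-yl)propyl group, so the contribution of the hydroxy group cannot be separated from that of the chain, since every step to compound 4 also alters the ring or the chain. Going by these compounds, whether a 4-methoxypiperidin-1-yl or 4-aminopiperidin-1-yl group on the same chain would behave like the 4-hydroxypiperidin-1-yl group also remains open.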